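Swapping Nitro for Methoxy in a Cytotoxicity Series

The source may hold more compounds than are shown below. What is called first, only, known or untested is meant among the compounds shown, and "the series" means these compounds.

Of the compounds shown here, three built on one shared core have been tested in an ADME assay on L929 cells (Mus musculus) for cytotoxicity, read by MTT assay, with a stated time of 72 h; on this read-out lower numbers stand for higher toxicity in this test and higher numbers for lower toxicity in this test. Compound 1 `CCOC(=O)c1[nH]c(=O)c(C#N)cc1C(=O)c1ccc(Cl)cc1` gives 218000 nM, compound 2 `CCOC(=O)c1[nH]c(=O)c(C#N)cc1C(=O)c1ccc(C)cc1` gives 512000 nM, and compound 3 `CCOC(=O)c1[nH]c(=O)c(C#N)cc1C(=O)c1ccc([N+](=O)[O-])cc1` gives 213000 nM. Compound 3 sits at the low end of these numbers: a 1.0-fold lower number from compound 1 to compound 3 (0.01 log units; within the scatter), whereas a 2.4-fold lower number from compound 2 to compound 3 (0.38 log units; beyond the scatter). Compound 4 `CCOC(=O)c1[nH]c(=O)c(C#N)cc1C(=O)c1ccc(OC)cc1` differs from compound 3 in one place, (methoxy in place of nitro on an aromatic carbon). Within the data shown here, no measured step exchanges nitro for methoxy directly; the nearest guides are the two steps already named and a 2.3-fold higher number from compound 1 to compound 2 (0.37 log units; beyond the scatter), all of which show that changing this group shifts this assay by no more than modest amounts. The expected step is therefore a 1.6-fold higher number from compound 3 to compound 4 (0.22 log units; within the scatter). Compound 4 is estimated at about 350000 nM, within 150000 nM to 800000 nM.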

Compound 4, half-maximal cytotoxic concentration: 259000 nM
For compound 4 the middle estimate is 1.4-fold (0.13 log units) above the measured one, and the stated range covers the measured number.
By their numbers in this assay, from the lowest: compounds 3, 1, 4 and 2 (each within the scatter of the next, the first and the last beyond it).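

Methoxy, on an aromatic carbon para to a large group, stays within the scatter of all three earlier groups (a 1.2-fold higher number from compound 3 to compound 4 (0.08 log units; within the scatter)) (a 1.2-fold higher number from compound 1 to compound 4 (0.07 log units; within the scatter)) (a 2.0-fold lower number from compound 2 to compound 4 (0.30 log units; within the scatter)). Compound 4 therefore cannot be assigned to either side of the modest gap between compound 2 and compound 3, so a fourth group adds no clear separation at this position. No supporting measurement explains this result.

On these data alone, whether an amine, a carboxylic acid or a longer chain at this carbon would stay in the same range remains open. So does whether any group here can shift the number by more than a modest amount.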